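Para-fluoro on the benzamide of compound 2

This account rests on a few compounds, and the source may have more. Where it says the series, first, only, none or still open, it means among the compounds named here.

Measured so far:
- Compound 1, `COc1cccc(-c2nn(-c3ccccc3)cc2-c2ccnc(NCCNC(=O)Nc3cccc(C(F)(F)F)c3)c2)c1`: in a functional assay on COLO 205 cells (Homo sapiens) for cytotoxicity (on this read-out higher numbers stand for lower toxicity in this test and lower numbers for higher toxicity in this test), compound 1 gives 6950 nM.
- Compound 2, `O=C(NCCCNc1cc(-c2cn(-c3ccccc3)nc2-c2cccc(O)c2)ccn1)c1ccccc1`: in this assay compound 2 gives 7880 nM.

Compound 2 has the highest of the two numbers, but its nearest neighbour, compound 1, sits within the scatter of it, so the two values show no difference that can be read as real. Both compounds share the same pyrazole-bearing core and differ in the side chain beyond the amine.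

Compound 3, `O=C(NCCCNc1cc(-c2cn(-c3ccccc3)nc2-c2cccc(O)c2)ccn1)c1ccc(F)cc1`, has not yet been measured in this assay. It differs from compound 2 in one place: fluoro in place of hydrogen on an aromatic carbon. For the measured compounds named here, no pair of measured compounds separated by such a change is available, so the size of the step has to be judged from the change alone. A single fluorine added on the far aromatic ring of the benzamide is a small alteration, and the account expects the step from compound 2 to compound 3 in this assay to be about a 1.1-fold lower number from compound 2 to compound 3 (0.02 log units; within the scatter), that is, none beyond the scatter in either direction. Compound 3 is accordingly estimated at 7500 nM, with a range from 3000 nM to 18000 nM.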

Compound 3, concentration lethal to 50% of the cells: 7600 nM
Beside the measured number, compound 3's estimate is 1.0-fold (0.01 log units) below it, and the stated range covers the measured number.
By their numbers in this assay, from the lowest: compounds 1, 3 and 2 (each within the scatter of the next).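

For the compounds shown here, the pair of compound 2 and compound 3 gives the first step between compounds that differ in one place: in this assay, the reading is a 1.0-fold lower number from compound 2 to compound 3 (0.02 log units; within the scatter). At this position, on an aromatic carbon para to a large group, phenyl and 4-fluorophenyl therefore cannot be told apart on this read-out, something compound 1 and compound 2 could not show, as they differ in more than one place. Nothing available here accounts for this result.

The compounds shown leave open whether a chloro, a methoxy or an amine in place of the fluoro would give a number beyond the scatter, and whether fluoro on another carbon of the same ring would read as this one does. They also leave open what a longer chain between the amide and the shared core would do, since the one other side chain shown, in compound 1, comes with further differences and gives no step.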